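This account rests on a few compounds, and the source may have more. Where it says the series, first, only, none or still open, it means among the compounds named here.

In an assay on membranes from striatum (strain Sprague-Dawley) for displacement of a labelled ligand from sodium-dependent dopamine transporter (Rattus norvegicus), read by scintillation counting, with a stated time of 120 min (on this read-out higher numbers stand for weaker inhibition and lower numbers for stronger inhibition), compound 2 `Fc1ccc(C(SCCNC2CCN(Cc3ccc(C(F)(F)F)cc3)CC2)c2ccc(F)cc2)cc1` gives 190 nM, the highest of the three numbers recorded; compound 1 `Fc1ccc(C(SCCNC2CCN(Cc3ccc(Cl)cc3)CC2)c2ccc(F)cc2)cc1` gives 39.6 nM and compound 3 `[O-][S+](CCNC1CCN(Cc2ccc(F)cc2)CC1)C(c1ccc(F)cc1)c1ccc(F)cc1` gives 50.6 nM. For the measured compounds named here, the only single-point step among them, a 4.8-fold higher number from compound 1 to compound 2 (0.68 log units; beyond the scatter), leads toward compound 2. Compound 4 `O=C(c1ccc(F)cc1)N1CCC(NCCSC(c2ccc(F)cc2)c2ccc(F)cc2)CC1` carries (4-fluorophenyl)carbonyl in place of 4-(trifluoromethyl)benzyl on an amine nitrogen in a ring. Going by the values given here, no measured step alters the group on this ring nitrogen in that way, and the step from compound 2 to compound 4 cannot be read off directly. Among the compounds with values here, the lower numbers of compound 1 and compound 3, each bearing a benzyl with a single halogen, leave room for a smaller number than compound 2, yet the incoming carbonyl group has no measured counterpart. Compound 4 is therefore expected at 120 nM, a step of a 1.6-fold lower number from compound 2 to compound 4 (0.20 log units; within the scatter), within 30 nM to 500 nM.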

Compound 4, inhibition constant: 7.04 nM
The estimate for compound 4 lay 17-fold (1.23 log units) above the measured number; measured number outside the range, below it.
By their numbers in this assay, from the lowest: compound 4; then compounds 1 and 3 (each within the scatter of the next); then compound 2.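

In this assay, the group on the ring nitrogen moves the number further than the earlier change on the benzyl ring did: (4-fluorophenyl)carbonyl gives a 27-fold lower number from compound 2 to compound 4 (1.43 log units; beyond the scatter) and a 5.6-fold lower number from compound 1 to compound 4 (0.75 log units; beyond the scatter). So a benzyl is not required on this nitrogen, and the carbonyl-linked group gives the lower number in both comparisons. Nothing available explains this result.

Going by these compounds, the carbonyl and the ring substituent change together here, so their separate shares stay open. Also open, on these data alone, is how a sulfonyl or a longer chain on this nitrogen would read.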